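Sulfonyl aryl variation on a shared diarylaminopyrimidine core

The compounds below may be only part of what the source reports. "The series", "measured", "known", "first", "only" and "open" are said of these compounds alone.

Measured compounds:
- compound 1, `Cc1cc(Nc2ccc(F)cc2)nc(Nc2ccc(NS(=O)(=O)c3ccc(C(F)(F)F)cc3)cc2)n1`, 32300 nM in a functional assay on MDA-MB-468 cells (Homo sapiens) for antiproliferative activity, read by MTT assay; on this read-out higher numbers stand for weaker inhibition and lower numbers for stronger inhibition
- compound 2, `Cc1cc(Nc2ccc(F)cc2)nc(Nc2ccc(NS(=O)(=O)c3ccccc3OC(F)(F)F)cc2)n1`, 42200 nM in this assay

Compound 2 holds the highest of the two numbers in this assay; its nearest neighbour is compound 1, and the step of a 1.3-fold higher number from compound 1 to compound 2 (0.12 log units; within the scatter) lies within the scatter, so the two show no ordering on this read-out.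

Compound 3, `COc1cc(C)cc(Cl)c1S(=O)(=O)Nc1ccc(Nc2nc(C)cc(Nc3ccc(F)cc3)n2)cc1`, is not yet measured. It differs from compound 2 at the sulfonyl sulfur: 2-chloro-6-methoxy-4-methylphenyl in place of 2-(trifluoromethoxy)phenyl on a sulfonyl sulfur. Within the data shown here, the only measured step that bears on this position is a 1.3-fold higher number from compound 1 to compound 2 (0.12 log units; within the scatter), an exchange of one aryl group for another on the same sulfur that produced no change beyond the scatter. On that basis the step of a 1.1-fold lower number from compound 2 to compound 3 (0.02 log units; within the scatter) is expected to stay within the scatter as well, with no direction assigned. Compound 3 is therefore estimated at 40000 nM in this assay, within a range of 15000 nM to 100000 nM.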

Compound 3, half-maximal inhibitory concentration: > 50000 nM
Compound 3: no number, only a limit (the forecaster's own chance of this, stated with the estimate: 15%); middle value at least 1.2-fold (0.09 log units) from the limit.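

Compound 3 gives > 50000 nM in this assay, which is a limit and not a number. The steps are floors only, an at least 1.1-fold higher number from compound 2 to compound 3 (0.07 log units; that floor lies within the scatter) and an at least 1.5-fold higher number from compound 1 to compound 3 (0.18 log units; that floor lies within the scatter), so they fix no order among the three compounds, though they do show that 2-chloro-6-methoxy-4-methylphenyl on the sulfonyl sulfur brings no move towards lower numbers. The earlier pair left that direction unsettled for a further aryl exchange, and the new information rests solely on one reading at the end of the range: the limit of > 50000 nM in this assay, at which 1 of the 3 values shown sits.

On these data alone, how far compound 3 actually lies from compound 1 and compound 2 stays unknown. Also open, as far as these compounds go, is whether an aryl group carrying an amine or a carboxylic acid, or a longer alkyl chain on the sulfonyl sulfur, would give lower numbers on this core.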